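The source may report more compounds than this note shows. Statements on the series, on what has been measured and on what is new or still open speak of the compounds shown alone.

Series notes. Compound 1 `Cc1ccc(OC(=O)/C=C/c2ccc(Cl)cc2Cl)c(C(C)C)c1` gives 0% in a functional assay on the whole organism for inhibition, with Brassica rapa subsp. chinensis as the target, with a stated time of 3 days, tested at 100 ppm; a higher number here means more inhibition of growth at the concentration tested, a lower number less inhibition of growth. Compound 3 `Cc1ccc(OC(=O)/C=C/c2ccc(Cl)cc2)c(C(C)C)c1` differs from compound 1 by hydrogen in place of chloro on an aromatic carbon; in this assay compound 3 gives 18%, the step being a number 18 percentage points higher from compound 1 to compound 3 (beyond the scatter). Compound 2 `O=C(/C=C/c1ccccc1)NCc1ccc(Cl)cc1Cl` rests on a different core; the difference between the two cores is not broken down here. In this assay compound 2 gives 43%, the highest of the three measured numbers. Compound 4 `O=C(/C=C/c1ccccc1)NCc1ccc(Cl)cc1` has not been measured. It differs from compound 2 by hydrogen in place of chloro on an aromatic carbon, the same kind of change as from compound 1 to compound 3, the place being described in the same words for both pairs. That change gave a number 18 percentage points higher from compound 1 to compound 3 (beyond the scatter). On that basis compound 4 is expected to gain over compound 2, with an estimated step of a number 12 percentage points higher from compound 2 to compound 4 (beyond the scatter), though the differing core leaves the size uncertain. For compound 4 the estimate is 55%, expected between 30% and 80%.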

Compound 4, percent growth inhibition at one concentration: 44%
For compound 4 the middle estimate is 11 percentage points above the measured one; the measured number falls inside the stated range.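

On the core of compound 2, replacing chloro by hydrogen on an aromatic carbon gives, in this assay, a number 1 percentage points higher from compound 2 to compound 4 (within the scatter). The size of this step does not carry over between the two cores: the same change on two cores in this assay, a number 18 percentage points higher (beyond the scatter) from compound 1 to compound 3 and a number 1 percentage points higher (within the scatter) from compound 2 to compound 4, 17 percentage points apart, beyond the scatter of two such steps

This comparison rests on one pair per core, tested at one concentration, and shows nothing about the same change on any other core or which part of the cores separates the two steps.

The compounds shown leave open whether a methoxy group or a nitrile in place of the chloro group would also differ between the two cores. They also leave open whether a fluoro group there would behave as hydrogen does.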